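A few compounds are considered here, and "the series" means these few. Any claim that something is new, unique, unknown or untested is made for them only; others in the source may bear on it.

Measured so far:
- compound 1, `Cc1cccc(Nc2nc(-c3ccncc3C#CCCCO)cs2)c1`: 6300 nM; 1120 nM (2 entries)
- compound 2, `Cc1cccc(Nc2nc(-c3ccncc3-c3ccc(C(C)C)cc3)cs2)c1`: > 40000 nM; 40700 nM (2 entries)
- compound 3, `C#Cc1cnccc1-c1csc(Nc2cccc(C)c2)n1`: 1380 nM

These three compounds share one core and differ only in the group carried on the six-membered ring with one nitrogen. In a functional assay on RCC4 cells (Homo sapiens) for inhibition, read by XTT assay, with a stated time of 4 days (a lower number here means a stronger inhibitor, a higher number a weaker inhibitor), compound 1 gives 6300 nM; 1120 nM (2 entries), two entries that do not agree closely with each other, as the several entries of compound 1 in this assay, 6300 nM; 1120 nM (2 entries) shows. For compound 2 the first of its entries is a limit of the assay rather than a number, and its second entry, (the several entries of compound 2 in this assay, > 40000 nM; 40700 nM (2 entries)), sits far from the values of the other two compounds. Going by the values given here, compound 3, which carries an ethynyl group on that ring, gives 1380 nM; this is the only single number recorded for it, since two further entries carry no number.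

Compound 4, `Cc1cccc(Nc2nc(-c3ccncc3CCCO)cs2)c1`, has not yet been measured. It differs from compound 3 in one place: 3-hydroxypropyl in place of ethynyl on an aromatic carbon. Among the compounds with values here, no step between two measured compounds matches this change, so the size of the step from compound 3 to compound 4 can only be guessed from the spread of numbers above. Compound 1, which also carries a hydroxyl-ended chain, is expected to be the nearest guide, and its entries in this assay lie close to that of compound 3. The step of a 1.8-fold higher number from compound 3 to compound 4 (0.26 log units; within the scatter) is therefore expected to be small, within or barely beyond the scatter, and probably toward a weaker inhibitor. Compound 4 is estimated to give 2500 nM in this assay, between 700 nM and 9000 nM.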

Compound 4, half-maximal inhibitory concentration: 6920 nM
The estimate for compound 4 lay 2.8-fold (0.44 log units) below the measured number, within the range that was stated.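

In this assay, putting 3-hydroxypropyl in place of ethynyl gives a 5.0-fold higher number from compound 3 to compound 4 (0.70 log units; beyond the scatter). This is the only step shown between measured compounds that differ in one place, and so the first direct reading of this position, on an aromatic carbon ortho to a large group and two atoms from the ring nitrogen: the change brings in one hydrogen-bond donor and one hydrogen-bond acceptor, and inhibition weakens by a modest amount but is not lost. The step rests on a single number for compound 3, and compound 1, which also carries a chain ending in a hydroxyl, shows how far repeated entries can spread in this assay: the several entries of compound 1 in this assay, 6300 nM; 1120 nM (2 entries)

The compounds shown do not separate the three parts of this change: the loss of the triple bond, the longer chain and the hydroxyl at its end. Going by these compounds, whether a plain propyl chain, or a chain of the same length ending in an amine or a carboxylic acid, would behave like 3-hydroxypropyl at this position remains open.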